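A few compounds are considered here, and "the series" means these few. Any claim that something is new, unique, unknown or untested is made for them only; others in the source may bear on it.

Three compounds of the series have numbers in an assay on isolated protein for inhibition of Apoptosis regulator Bcl-2 (Homo sapiens), read by surface plasmon resonance, with a stated time of 1 h; a higher number here means a weaker inhibitor, a lower number a stronger inhibitor. Compound 1 `CN(C)CC[C@H](CSc1ccccc1)Nc1ccc(S(=O)(=O)Nc2ncnc3c2CCN(C2CCN(Cc4ccccc4-c4ccc(Cl)cc4)CC2)C3)cc1S(=O)(=O)C(F)(F)F` gives 19 nM. Compound 2 `CC(c1ccccc1-c1ccc(Cl)cc1)N1CCC(N2CCc3c(ncnc3NS(=O)(=O)c3ccc(N[C@H](CCN(C)C)CSc4ccccc4)c(S(=O)(=O)C(F)(F)F)c3)C2)CC1` gives 35 nM, and compound 3 `CN(C)CC[C@H](CSc1ccccc1)Nc1ccc(S(=O)(=O)Nc2nc(Cl)nc3c2CCN(C2CCN(Cc4ccccc4-c4ccc(Cl)cc4)CC2)C3)cc1S(=O)(=O)C(F)(F)F` gives 32 nM. On these numbers compound 3 stands second highest of the three; its nearest neighbour is compound 2, its furthest is compound 1, and both gaps lie within the scatter. The two single-point steps that connect the measured set, a 1.8-fold higher number from compound 1 to compound 2 (0.27 log units; within the scatter) and a 1.7-fold higher number from compound 1 to compound 3 (0.23 log units; within the scatter), are likewise within the scatter. Compound 4 `CN(C)CC[C@H](CSc1ccccc1)Nc1ccc(S(=O)(=O)Nc2nc(C(F)(F)F)nc3c2CCN(C2CCN(Cc4ccccc4-c4ccc(Cl)cc4)CC2)C3)cc1S(=O)(=O)C(F)(F)F` differs from compound 3 by trifluoromethyl in place of chloro on an aromatic carbon. For the measured compounds named here, the only measured step at this ring position is the one from compound 1 to compound 3, which stayed within the scatter; no measured step covers an exchange of chloro for trifluoromethyl, so the bearing of the earlier steps is indirect. On that basis the expected step in this assay is a 1.1-fold higher number from compound 3 to compound 4 (0.04 log units; within the scatter), that is, none beyond the scatter. Compound 4 is accordingly estimated at 35 nM, with a range from 14 nM to 90 nM.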

Compound 4, half-maximal inhibitory concentration: 46 nM
Compound 4: the middle estimate sits 1.3-fold (0.12 log units) below what was measured; the range from low to high includes it.
By their numbers in this assay, from the lowest: compounds 1, 3, 2 and 4 (each within the scatter of the next, the first and the last beyond it).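

The aromatic carbon between two ring nitrogen atoms tolerates trifluoromethyl, with 4 heavy atoms, in place of chloro, with 1 heavy atom: in this assay the exchange gives a 1.4-fold higher number from compound 3 to compound 4 (0.16 log units; within the scatter). For the compounds shown here, measured against the unsubstituted compound 1, however, trifluoromethyl gives a 2.4-fold higher number from compound 1 to compound 4 (0.38 log units; beyond the scatter), the first step at this position to pass beyond the scatter, and a modest one. No supporting data bear on the reason for this step.

Still open, on these data alone, is how an amine, a methoxy group or a phenyl ring on this carbon would read in this assay, and so whether any group here can match or improve on hydrogen. Also open, as far as these compounds go, is whether trifluoromethyl here would read the same alongside the methyl group that compound 2 carries on its chain carbon.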